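Ethyl on the Saturated Ring Carbon: Compound 2 to Compound 3

The source may report more compounds than this note shows. Statements on the series, on what has been measured and on what is new or still open speak of the compounds shown alone.

Compound 1, `CC[C@@H]1c2cc(Cl)ccc2C(=O)N1c1cncc2c1CCC[C@H]2NC(C)=O`: 7 nM
Compound 2, `CCC(=O)N[C@@H]1CCCc2c1cncc2N1Cc2cc(Cl)ccc2C1=O`: 28 nM

In an assay on cells for inhibition of cytochrome P450 11B2, mitochondrial (Homo sapiens), read by HTRF (a higher number here means a weaker inhibitor, a lower number a stronger inhibitor), compound 2 gives 28 nM, the higher of the two numbers shown. Compound 1 gives 7 nM in this assay, a lower number that lies beyond the usual scatter, so compound 2 stands as the weaker of the two measured compounds.

Compound 3, `CCC(=O)N[C@@H]1CCCc2c1cncc2N1C(=O)c2ccc(Cl)cc2[C@H]1CC`, has not yet been measured. It differs from compound 2 by ethyl in place of hydrogen on a saturated ring carbon. For the measured compounds named here, no measured pair shows this change by itself, so its size can only be guessed. The two measured values show that numbers in this small set can sit well below that of compound 2, and the change is expected to move the number downward by a moderate step, a 2.8-fold lower number from compound 2 to compound 3 (0.45 log units; beyond the scatter). Compound 3 is therefore estimated at 10 nM, with a range from 3 nM to 35 nM.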

Compound 3, half-maximal inhibitory concentration: 90 nM
Beside the measured number, compound 3's estimate is 9.0-fold (0.95 log units) below it, and the stated range ends below it.
By their numbers in this assay, from the lowest: compound 1; then compound 2; then compound 3.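

In this assay, ethyl in place of hydrogen on a saturated ring carbon, next to the ring nitrogen, does not lower the number but gives a 3.2-fold higher number from compound 2 to compound 3 (0.51 log units; beyond the scatter) as a modest loss. The ethyl group does not by itself fix a high number, since compound 1 carries it and gives 7 nM in this assay, and a change of the chain alone gives the large step of a 13-fold higher number from compound 1 to compound 3 (1.11 log units; beyond the scatter) on the same ethyl-bearing core. Nothing available explains either step.

Going by these compounds, how a methyl or a cyclopropyl on that ring carbon would compare with hydrogen and ethyl remains open. Also open, on these data alone, is whether the ethyl step keeps its direction and size on the shorter chain of compound 1.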